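This account rests on a few compounds, and the source may have more. Where it says the series, first, only, none or still open, it means among the compounds named here.

Compound 1 `CN1CCC(n2cc(S(=O)(=O)c3ccc(F)cc3)c3cccnc32)C1` and compound 2 `CN1CCC(n2cc(S(=O)(=O)c3ccc(Cl)cc3)c3cccnc32)C1` share one core, while compound 3 `CCN1CCC(n2cc(S(=O)(=O)c3cccc(F)c3)c3cccnc32)C1` and compound 4 `CCN1CCC(n2cc(S(=O)(=O)c3cccc(Cl)c3)c3cccnc32)C1` share another; the difference between the two cores is not broken down here. In an assay on HeLa cells for displacement of a labelled ligand from 5-hydroxytryptamine receptor 6 (Homo sapiens) (a lower number here means a stronger inhibitor, a higher number a weaker inhibitor), compound 1 gives 5 nM and compound 2 gives 4.2 nM; the step of a 1.2-fold lower number from compound 1 to compound 2 (0.08 log units; within the scatter) accompanies the change (chloro in place of fluoro on an aromatic carbon). In this assay compound 3 gives 8.3 nM. Compound 4 carries the same kind of change, (chloro in place of fluoro on an aromatic carbon), which sits para to a large group in compound 2 but meta to a large group in compound 4. Because the step of a 1.2-fold lower number from compound 1 to compound 2 (0.08 log units; within the scatter) stays within the scatter, the step of a 1.2-fold lower number from compound 3 to compound 4 (0.07 log units; within the scatter) is expected to be about as small. Compound 4 is therefore estimated at 7 nM in this assay, between 3.5 nM and 14 nM.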

Compound 4, inhibition constant: 3.3 nM
Compound 4: the middle estimate sits 2.1-fold (0.33 log units) above what was measured; the measured number lies below the stated range.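

In this assay, chloro in place of fluoro gives a 2.5-fold lower number from compound 3 to compound 4 (0.40 log units; beyond the scatter). Set beside the earlier step, this one does not differ from it by more than the scatter of two such steps allows: the same change on two cores in this assay, a 1.2-fold lower number (0.08 log units; within the scatter) from compound 1 to compound 2 and a 2.5-fold lower number (0.40 log units; beyond the scatter) from compound 3 to compound 4, 2.1-fold (0.32 log units) apart, within the scatter of two such steps. Among these compounds, the change therefore carries from one core to the other without a detectable difference in the size of its step, but this does not show that the size is the same on both, as only two pairs are compared and the chloro of compound 4 sits meta to a large group, unlike that of compound 2. The compounds shown leave open how a bromo or a methoxy group in that place would read in this assay, and whether 3-fluorophenyl to 3-chlorophenyl gives a similar step on the core of compound 1.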